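This account rests on a few compounds, and the source may have more. Where it says the series, first, only, none or still open, it means among the compounds named here.

Compound 1 `Cc1cccc(NC(=O)Nc2ccc(Oc3ncnc4[nH]ncc34)cc2)c1C` gives > 10000 nM
Compound 2 `O=C(Nc1ccc(Oc2ncnc3[nH]ncc23)cc1)c1ccc(Br)cc1` gives > 10000 nM

Both entries come from a functional assay on HeLa cells (Homo sapiens) for inhibition, read by MTT assay, with a stated time of 72 h (a lower number here means a stronger inhibitor, a higher number a weaker inhibitor), and each is a limit, not a number. As far as these compounds go, compound 1 stands at > 10000 nM and this is a limit, so its true potency is unknown. The whole picture so far is the limit of > 10000 nM in this assay, at which 2 of the 2 values shown sit, and nothing more.

Compound 3 `CC(C)c1cccc(NC(=O)Nc2ccc(Oc3ncnc4[nH]ncc34)cc2)c1` has 3-isopropylphenyl in place of 2,3-dimethylphenyl on an amide-type nitrogen, and the count of that change is 3-isopropylphenyl in place of 2,3-dimethylphenyl on an amide-type nitrogen in full. Among the compounds with values here, the only measured step is a step that the two limits leave unreadable from compound 1 to compound 2 and it offers no size or direction to borrow. No clear shift is therefore expected in this assay and the expected step is a step that the limit leaves unreadable from compound 1 to compound 3 as an estimate only. Compound 3 is estimated at 12000 nM with an expected range of 3000 nM to 40000 nM and may also come back as a limit only.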

Compound 3, half-maximal inhibitory concentration: > 10000 nM
Compound 3: a limit, no number (the forecaster's own chance of this, stated with the estimate: 70%); the middle value lies beyond the limit too.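

In this assay compound 3 gives > 10000 nM, which is a limit and not a number. Within the data shown here, compound 1 and compound 2 also stand only at limits, so no step from compound 1 to compound 2 or to compound 3 can be read. Still open, as far as these compounds go, is how far each compound lies past its limit, and whether any change on the shared core gives a real number in this assay.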